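The source may report more compounds than this note shows. Statements on the series, on what has been measured and on what is new or still open speak of the compounds shown alone.

Measured so far:
compound 1 `CCC(CC)(c1ccc(OCCCCO)c(C)c1)c1ccc(OCC(O)C(C)(C)C)c(OCC(O)C(C)(C)C)c1`: 71%
compound 2 `CCC(CC)(c1ccc(OCCCC(=O)O)c(C)c1)c1ccc(OCC(O)C(C)(C)C)c(OCC(O)C(C)(C)C)c1`: 14%
compound 3 `CCC(CC)(c1ccc(OCCCCC(=O)O)c(C)c1)c1ccc(OCC(O)C(C)(C)C)c(OCC(O)C(C)(C)C)c1`: "not active" (no number reported)

In an assay on cells for binding affinity to vitamin D3 receptor (Homo sapiens), read by fluorescence, tested at 1 uM (on this read-out higher numbers stand for more inhibition at the one concentration tested (going by the name of the read-out) and lower numbers for less inhibition), compound 1 stands highest of the two numbers shown; compound 2 lies well below it, and for compound 3 no number was reported. Compound 4 `CCC(CC)(c1ccc(OCCCCCCC(=O)O)c(C)c1)c1ccc(OCC(O)C(C)(C)C)c(OCC(O)C(C)(C)C)c1` is not yet measured. Against compound 1 the change is 2-carboxyethyl in place of hydroxy on a saturated chain carbon, four bonds along the chain from an oxygen on an aromatic ring. Among the measured compounds shown here, the one step that bears on it is a number 57 percentage points lower from compound 1 to compound 2 (beyond the scatter), a large fall beyond the scatter, and the longer acid of compound 3 gave no number at all. A similar large fall is therefore expected for compound 4, a number 61 percentage points lower from compound 1 to compound 4 (beyond the scatter). For compound 4 the expected value in this assay is 10%, in the range 0% to 30%.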

Compound 4, a percentage reported as inhibition, at one concentration (the size of the read-out at that concentration, not a potency): "not active" (no number reported)
The entry for compound 4 holds no number, so the estimate cannot be set against anything.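

Among the compounds shown here, compound 4, like compound 3, is entered as "not active" with no number, so no new step against compound 1 can be read, and no evidence bears on this result. The compounds shown leave open how the read-outs of compound 3 and compound 4 compare with that of compound 2.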